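A few compounds are considered here, and "the series" means these few. Any claim that something is new, unique, unknown or untested is made for them only; others in the source may bear on it.

Measured compounds:
Compound 1 `COc1ccc(CN(C(=O)CSC(=S)N2CCN(C(=O)OC(C)(C)C)CC2)c2ccc(Br)cc2)cc1` in a functional assay on KYSE-450 cells (Homo sapiens) for inhibition, read by CCK-8 assay, with a stated time of 48 h (on this read-out higher numbers stand for weaker inhibition and lower numbers for stronger inhibition), gives > 20000 nM, which is a limit of the assay and not a number.
Compound 2 `COc1ccc(CN(C(=O)CSC(=S)N2CCN(C(=O)OC(C)(C)C)CC2)c2ccc(C)cc2)cc1` in this assay gives > 20000 nM, which is likewise a limit and not a number.
Going by the values given here, compound 3 `COc1ccc(CN(C(=O)CSC(=S)N2CCN(C(=O)OC(C)(C)C)CC2)c2cc(OC)c(OC)c(OC)c2)cc1Br` in this assay gives 1850 nM, the only number in the set so far.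

Compound 4 `COc1ccc(CN(C(=O)CSC(=S)N2CCN(C(=O)OC(C)(C)C)CC2)c2cc(OC)c(OC)c(OC)c2)cc1C` is not yet measured in this assay. It differs from compound 3 by methyl in place of bromo on an aromatic carbon. The same exchange has been made once before, from compound 1 to compound 2, as methyl in place of bromo on an aromatic carbon. The two places are not the same: in the pair compound 1 and compound 2 the carbon is para to a large group, whereas in compound 3 and compound 4 it is ortho to a methoxy group and meta to a large group, so this is the same kind of change rather than the same change. How the core of compound 3 differs from the core of compound 1 is not broken down here.

The earlier step, a step that the two limits leave unreadable from compound 1 to compound 2, has no readable size because both values sit at the limit of > 20000 nM in this assay, at which 2 of the 3 values shown sit. It therefore gives no direction for the new pair beyond showing that the exchange did not lift either compound into the measurable range. In this assay the step from compound 3 to compound 4 is expected to be small, a 1.4-fold higher number from compound 3 to compound 4 (0.13 log units; within the scatter), resting on the value of compound 3 at 1850 nM as the only anchor. Compound 4 is accordingly estimated at 2500 nM, expected to fall between 900 nM and 7000 nM.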

Compound 4, half-maximal inhibitory concentration: > 20000 nM
Compound 4 was reported as a limit; the forecaster's own chance of this, stated with the estimate: 10%; middle value at least 8.0-fold (0.90 log units) away from the limit.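

In this assay, methyl in place of bromo on the aromatic carbon ortho to a methoxy group gives an at least 10-fold higher number from compound 3 to compound 4 (1.03 log units; beyond the scatter), a large step and the only readable measure of this exchange in the series. Compound 4 gives > 20000 nM, which is a limit of the assay and not a number, so the step shows a loss of measurable inhibition on the core of compound 3 but not its full size. The earlier exchange from compound 1 to compound 2 cannot be read and sits at a different place on a different core, so the data do not show whether the outcome of this change carries from one core to another, and most of the set offers no number for such a comparison: the limit of > 20000 nM in this assay, at which 3 of the 4 values shown sit.

Still open, from the compounds shown here alone, is whether the value of compound 3 depends on bromo in particular, or whether chloro, a nitrile or an amine on the same aromatic carbon would also keep a measurable value. Also open, going by these compounds, is whether the 3-bromo-4-methoxybenzyl group would bring a measurable value on the core of compound 1, which would separate the contribution of bromo from that of the core.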